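Mirror image of the most potent compound

The source may hold more compounds than are shown below. What is called first, only, known or untested is meant among the compounds shown, and "the series" means these compounds.

In all, three compounds were tested in a functional assay on HEK293 cells for agonist activity at Neuronal acetylcholine receptor; alpha3/beta4 (Homo sapiens), read by FLIPR; a higher number here means that more compound is needed for the effect, a lower number that less compound is needed. Compound 1 `COc1cc(N2C[C@@H]3CCNC[C@@H]32)cnc1Br` gives 2980 nM, compound 2 `N#Cc1cc(N2C[C@H]3CCNC[C@H]32)cnc1Br` gives 238 nM, and compound 3 `Clc1ccc(N2CC[C@H]3CN[C@H]3C2)nn1` gives 64.8 nM, the lowest of the three numbers, beyond the scatter from both compound 2 and compound 1. Compound 4 `Clc1ccc(N2CC[C@@H]3CN[C@@H]3C2)nn1` is the next case: the two compounds have the same atoms and bonds and differ only in configuration as drawn: 2 of 2 stereo elements differ (all stereocentres are inverted: mirror images); a stereocentre at a saturated ring carbon is drawn S in compound 3 and R in compound 4; a stereocentre at a saturated ring carbon is drawn R in compound 3 and S in compound 4. Within the data shown here, no pair among the measured compounds differs only in configuration, so the size of such a step in this assay is unknown from these data; because the number for compound 3 64.8 nM is the lowest seen, the inverted configuration is expected to move upward, with wide uncertainty, by a 6.2-fold higher number from compound 3 to compound 4 (0.79 log units; beyond the scatter). Compound 4 is therefore estimated at 400 nM, between 60 nM and 3000 nM.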

Compound 4, half-maximal effective concentration: 394 nM
The estimate for compound 4 lay 1.0-fold (0.01 log units) above the measured number; the measured number falls inside the stated range.
By their numbers in this assay, from the lowest: compound 3; then compounds 2 and 4 (each within the scatter of the next); then compound 1.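

In this assay, among these compounds, no earlier pair differed in one place only, so the size of a configuration change could not be read; inverting both stereocentres now gives a 6.1-fold higher number from compound 3 to compound 4 (0.78 log units; beyond the scatter). This step lies beyond the scatter and is the first that can be put down to configuration alone: the fact that compounds 3 and 4 differ only in the configuration as drawn

On these data alone, it remains open whether the same inversion would give a step of similar size on the core of compound 1 or compound 2. Also open, as far as these compounds go, is how an amine in place of the chlorine of compound 3 would read in this assay.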